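Stepping from compound 1 to compound 4

The source may hold more compounds than are shown below. What is called first, only, known or untested is meant among the compounds shown, and "the series" means these compounds.

Measured compounds:
- compound 1, `NCC(O)Cn1c(=O)n(C2OC(CO)[C@@H](O)[C@H]2O)c2nc(N)nc(O)c21`: 110%
- compound 2, `C=CCN1C(=C(C(=O)OCC)C(=O)OCC)N([C@H]2OC(CO)[C@H]3OC(C)(C)O[C@H]32)c2cc(N)nc(O)c21`: 0%
- compound 3, `C=CCn1c(=S)n([C@@H]2O[C@H](CO)[C@H]3OC(C)(C)O[C@H]32)c2nc(N)nc(O)c21`: 89%

All three were tested in a functional assay on the whole organism (B cells) with Mus musculus as the target; on this read-out higher numbers stand for larger maximal responses and lower numbers for smaller maximal responses. Compound 1 gives 110%, the highest of the three numbers. Compound 3 comes nearest, a number that lies beyond the usual scatter below compound 1. Compound 2 lies furthest away, with a response that is also well beyond the scatter below compound 1. No pair among these three differs in only one place, so none of the gaps can be pinned to a single structural change.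

Compound 4, `CCCCCCCCCCn1c(=O)n(C2OC(CO)[C@@H](O)[C@H]2O)c2nc(N)nc(O)c21`, has not yet been tested. Compared with compound 1 it carries one change: nonyl in place of 2-amino-1-hydroxyethyl on a saturated chain carbon bound to an aromatic nitrogen. For the measured compounds named here, nothing among the measured compounds shows what such a swap on this chain does in this assay, so the expected step rests on compound 1 alone.

For compound 4 in this assay, a smaller maximal response than that of compound 1 is expected, with the step of a number 50 percentage points lower from compound 1 to compound 4 (beyond the scatter) estimated as a drop beyond the scatter, but with wide uncertainty. The estimate for compound 4 is 60%, within a range from 10% to 110%.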

Compound 4, largest response reached (reported as maximal response), in percent of the reference or control that the assay uses: 0%
Estimate against measurement, compound 4: 60 percentage points above; the measured number lies below the stated range.
By their numbers in this assay, from the lowest: compounds 2 and 4 (each within the scatter of the next); then compound 3; then compound 1.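

In this assay, for the compounds shown here, replacing 2-amino-1-hydroxyethyl with nonyl on a saturated chain carbon bound to an aromatic nitrogen gives a number 110 percentage points lower from compound 1 to compound 4 (beyond the scatter) and is the first gap in this set that can be tied to a single structural change. It shows that this position is far from indifferent: with the rest of compound 1 left as it is, the chain alone separates a full response from none, so the shared core does not carry the response by itself. Nothing available here explains why this swap has such a large effect.

Going by these compounds alone, what remains open is which part of the change matters, since the one step both lengthens the chain and removes the amine and the hydroxyl together. A butyl chain, a 3-aminopropyl chain or a decyl chain ending in an amine could separate chain length from the loss of those groups, and could also show whether the response fades gradually along the chain or falls away suddenly.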